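This account rests on a few compounds, and the source may have more. Where it says the series, first, only, none or still open, it means among the compounds named here.

Of the compounds shown here, three sharing one core have been tested in a functional assay on T47D cells (Homo sapiens) for cytotoxicity, read by CCK-8 assay; a higher number here means a weaker inhibitor, a lower number a stronger inhibitor. Compound 1 `Oc1ccccc1-c1cc(-c2ccco2)cc(-c2ccccc2O)n1` carries two 2-hydroxyphenyl groups and a furan-2-yl group. In this assay compound 1 gives > 50000 nM, which is a limit of the assay rather than a number. Compound 2 `Oc1cccc(-c2cc(-c3ccco3)cc(-c3ccccc3O)n2)c1` differs by 3-hydroxyphenyl in place of 2-hydroxyphenyl on an aromatic carbon, and in this assay compound 2 gives 820 nM. The step is an at least 60-fold lower number from compound 1 to compound 2 (1.78 log units; beyond the scatter); it is stated as a bound because compound 1 sits at the limit of > 50000 nM in this assay, at which 2 of the 3 values shown sit. Compound 3 `Oc1cccc(-c2cc(-c3ccoc3)cc(-c3ccccc3O)n2)c1` is compound 2 with furan-3-yl in place of furan-2-yl, and in this assay compound 3 gives > 50000 nM, again a limit. That step is an at least 60-fold higher number from compound 2 to compound 3 (1.78 log units; beyond the scatter). The difference between the cores of compound 3 and compound 1 is not broken down here.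

Compound 4 `Oc1cccc(-c2cc(-c3ccoc3)cc(-c3cccc(O)c3)n2)c1` is not yet measured. It differs from compound 3 by 3-hydroxyphenyl in place of 2-hydroxyphenyl on an aromatic carbon. This is the same kind of change as from compound 1 to compound 2, though the surroundings differ: here the place is meta to a 3-hydroxyphenyl group and meta to a furan-3-yl group, whereas before it was meta to a 2-hydroxyphenyl group and meta to a furan-2-yl group. Beside an at least 60-fold lower number from compound 1 to compound 2 (1.78 log units; beyond the scatter), the expected step is an at least 3.3-fold lower number from compound 3 to compound 4 (0.52 log units; beyond the scatter), smaller and uncertain, because compound 3 starts at the limit > 50000 nM and the true distance is unknown. Compound 4 is estimated at 15000 nM, between 1500 nM and 80000 nM.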

Compound 4, half-maximal inhibitory concentration: 2590 nM
Beside the measured number, compound 4's estimate is 5.8-fold (0.76 log units) above it, and the stated range covers the measured number.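

In this assay, the change of 2-hydroxyphenyl to 3-hydroxyphenyl gives an at least 19-fold lower number from compound 3 to compound 4 (1.28 log units; beyond the scatter), so the same swap lowers the number on the core with a furan-3-yl group as it did on the core with a furan-2-yl group, and its direction carries over between these two cores. Compound 3 gives > 50000 nM, which is a limit of the assay and not a number, and the earlier step also starts from such a limit: the limit of > 50000 nM in this assay, at which 2 of the 4 values shown sit. The two steps therefore show a shared direction but no reliable size for either, so nothing can be said about whether the change is worth more on one core than on the other: the same change on two cores in this assay, an at least 60-fold lower number (1.78 log units; beyond the scatter) from compound 1 to compound 2 and an at least 19-fold lower number (1.28 log units; beyond the scatter) from compound 3 to compound 4; the limit leaves it open whether they differ.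

The compounds shown leave open how the furan-2-yl group would read on the core of compound 4, with its two 3-hydroxyphenyl groups, and so whether the choice of furan still matters once both hydroxyphenyl groups have this form. They also leave open whether the hydroxyl itself matters, since no plain phenyl, methoxyphenyl or aminophenyl group stands in its place here, and all of this rests on a single cell assay.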